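Series notes: isopropyl in place of isobutyl

A few compounds are considered here, and "the series" means these few. Any claim that something is new, unique, unknown or untested is made for them only; others in the source may bear on it.

Measured compounds:
- compound 1, `CC(C)[C@H](NC(=S)NCc1ccccc1)c1nc2ccccc2[nH]1`: 56100 nM
- compound 2, `CC(C)C[C@H](NC(=S)NCc1ccccc1)c1nc2ccccc2[nH]1`: 75700 nM
- compound 3, `CC(C)C[C@@H](NC(=S)Nc1cc(C(F)(F)F)cc(C(F)(F)F)c1)c1nc2ccccc2[nH]1`: 10200 nM

In a functional assay on A549 cells (Homo sapiens) for cytotoxicity, read by MTT assay (a higher number here means a weaker inhibitor, a lower number a stronger inhibitor), the three measured compounds sit as above; compound 3 gives the lowest number, and its steps to compound 1 and to compound 2 both lie beyond the scatter. The difference between compound 2 and compound 3 is not broken down here. Compound 4, `CC(C)[C@@H](NC(=S)Nc1cc(C(F)(F)F)cc(C(F)(F)F)c1)c1nc2ccccc2[nH]1`, is unmeasured; it differs from compound 3 by isopropyl in place of isobutyl on a saturated chain carbon bound to an amide-type nitrogen and an aromatic carbon. The same change, (isopropyl in place of isobutyl on a saturated chain carbon bound to an amide-type nitrogen and an aromatic carbon), is already measured once: a 1.3-fold lower number from compound 2 to compound 1 (0.13 log units; within the scatter). Because that step a 1.3-fold lower number from compound 2 to compound 1 (0.13 log units; within the scatter) is within the scatter, compound 4 is expected to sit close to compound 3, with a step of about a 1.3-fold lower number from compound 3 to compound 4 (0.11 log units; within the scatter). Compound 4 is therefore estimated at 8000 nM in this assay, with a likely range from 4000 nM to 20000 nM.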

Compound 4, half-maximal inhibitory concentration: 22400 nM
Beside the measured number, compound 4's estimate is 2.8-fold (0.45 log units) below it; measured number above the stated range.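

In this assay isopropyl in place of isobutyl gives a 2.2-fold higher number from compound 3 to compound 4 (0.34 log units; beyond the scatter) as a modest step on the core of compound 3. Read beside the earlier pair, the change does not carry over with the same size from one core to the other: the same change on two cores in this assay, a 1.3-fold lower number (0.13 log units; within the scatter) from compound 2 to compound 1 and a 2.2-fold higher number (0.34 log units; beyond the scatter) from compound 3 to compound 4, 3.0-fold (0.47 log units) apart, beyond the scatter of two such steps
This shows that the step on one core was a poor guide to the step on the other in this pair of cores, but it does not show what sets the gap, and two pairs give no rule for further cores.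

The compounds shown leave open how a longer chain, such as n-hexyl, or a cyclohexyl group would behave on that saturated chain carbon. From the compounds shown here alone, whether a carboxylic acid or an amine there would follow either step also stays open.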